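Sulfonyl-piperidine peroxides: liver-cell cytotoxicity across a halogen swap

The source may hold more compounds than are shown below. What is called first, only, known or untested is meant among the compounds shown, and "the series" means these compounds.

compound 1 `O=S(=O)(c1ccc(F)cc1)N1CCC2(CC1)OOC1(CCCC1)OO2`: > 100 ug/mL
compound 2 `O=S(=O)(c1ccc(F)cc1)N1CCC2(CC1)OOC1(CCCCC1)OO2`: > 100 ug/mL
compound 3 `O=S(=O)(c1ccc(Br)cc1F)N1CCC2(CC1)OOC1(CCCC1)OO2`: > 100 ug/mL

Compound 1, compound 2 and compound 3 were each tested in a functional assay on Huh-7 cells (Homo sapiens) for cytotoxicity, read by MTT assay, with a stated time of 72 h; on this read-out lower numbers stand for higher toxicity in this test and higher numbers for lower toxicity in this test. For compound 1 the result is only a limit of the test, > 100 ug/mL. For compound 2 likewise only a limit is reported, > 100 ug/mL. For compound 3 the value is again a limit, > 100 ug/mL. The change from compound 1 to compound 3 is 4-bromo-2-fluorophenyl in place of 4-fluorophenyl on a sulfonyl sulfur; its step, a step that the two limits leave unreadable from compound 1 to compound 3, cannot be read because both values sit at the limit of > 100 ug/mL in this assay, at which 3 of the 3 values shown sit. The difference between the cores of compound 1 and compound 2 is not broken down here. Compound 4 `O=S(=O)(c1ccc(Br)cc1F)N1CCC2(CC1)OOC1(CCCCC1)OO2` remains to be measured in this assay; it differs from compound 2 by the same change, (4-bromo-2-fluorophenyl in place of 4-fluorophenyl on a sulfonyl sulfur), at the same place. Since compound 2 sits at the limit of > 100 ug/mL in this assay, at which 3 of the 3 values shown sit, compound 4 is expected to show a step that the limit leaves unreadable from compound 2 to compound 4, with no readable step. Compound 4 is therefore estimated at 150 ug/mL, most likely reported again only as a limit.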

Compound 4, half-maximal cytotoxic concentration: > 100 ug/mL
Compound 4 gave a limit, no number; the forecaster's own chance of this, stated with the estimate: 85%; the middle value does not contradict the limit.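

Compound 4 gives only a limit in this assay, > 100 ug/mL. No step from compound 2 to compound 4 can be read, because both sit at the same limit: the limit of > 100 ug/mL in this assay, at which 4 of the 4 values shown sit.

The compounds shown leave open whether 4-bromo-2-fluorophenyl in place of 4-fluorophenyl changes toxicity in this assay at all.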